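A few compounds are considered here, and "the series" means these few. Any claim that something is new, unique, unknown or untested is made for them only; others in the source may bear on it.

Compound 1 `O=S(=O)(NCCNC(=S)Nc1cccc(Cl)c1)c1ccc(-c2ccccc2OCc2ccccc2)s1`: > 50000 nM (a limit)
Compound 2 `COc1cccc(NC(=O)NCCNS(=O)(=O)c2ccc(-c3ccccc3OCc3ccccc3)s2)c1`: > 20000 nM (a limit)
Compound 3 `O=[N+]([O-])c1ccc(NC(=S)NCCNS(=O)(=O)c2ccc(-c3ccccc3OCc3ccccc3)s2)cc1`: 11300 nM

Among the compounds with values here, in a functional assay on RS4-11 cells (Homo sapiens) for inhibition, read by CCK-8 assay, with a stated time of 48 h (on this read-out higher numbers stand for weaker inhibition and lower numbers for stronger inhibition), compound 3 gives 11300 nM, the only true number. Compound 4 `O=[N+]([O-])c1cccc(NC(=S)NCCNS(=O)(=O)c2ccc(-c3ccccc3OCc3ccccc3)s2)c1` differs from it as follows: 3-nitrophenyl in place of 4-nitrophenyl on an amide-type nitrogen. Within the data shown here, two measured steps bear on this. The step of an at least 4.4-fold lower number from compound 1 to compound 3 (0.64 log units; beyond the scatter) is at least modest and brings in 4-nitrophenyl in place of 3-chlorophenyl. The step of an at least 1.7-fold lower number from compound 2 to compound 3 (0.24 log units; that floor lies within the scatter) has a floor within the scatter. Neither step isolates the change made here, so only a small shift towards weaker inhibition is expected. The expected step is a 1.4-fold higher number from compound 3 to compound 4 (0.15 log units; within the scatter). For compound 4 the estimate is 16000 nM, with an expected range of 6000 nM to 45000 nM.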

Compound 4, half-maximal inhibitory concentration: 11600 nM
Beside the measured number, compound 4's estimate is 1.4-fold (0.14 log units) above it; measured number inside the range.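

In this assay, within the data shown here, a 1.0-fold higher number from compound 3 to compound 4 (0.01 log units; within the scatter) is the first direct read of 3-nitrophenyl in place of 4-nitrophenyl on an amide-type nitrogen, and these two nitro placements do not separate. Nitro in place of chloro on an aromatic carbon gives an at least 4.3-fold lower number from compound 1 to compound 4 (0.63 log units; beyond the scatter) as a floor only, the value of compound 1 being a limit. The step of an at least 1.7-fold lower number from compound 2 to compound 4 (0.23 log units; that floor lies within the scatter) likewise rests on a limit, that of compound 2.

Open, going by these compounds, is whether an amine or a carboxylic acid on the same phenyl ring would read apart from the nitro compounds. Nothing available bears on why the two nitro placements read alike.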